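Replacing a benzyl ester side chain with a hydroxyethyl group

The source may report more compounds than this note shows. Statements on the series, on what has been measured and on what is new or still open speak of the compounds shown alone.

Measured compounds:
compound 1, `O=C(CN(c1ncnc2c1ncn2C1CCCCO1)C1CC1)N[C@@H](CCC(=O)OCc1ccccc1)C(=O)OCc1ccccc1`, 14.1%
compound 2, `NCCCC[C@H](NC(=O)CN(c1nc(Cl)nc2[nH]cnc12)C1CC1)C(=O)OCc1ccccc1`, 9.88%

In a functional assay on the whole organism (Tail, strain ICR) with Mus musculus as the target, in the tail flick test, with a stated time of 150 min, at a dose of 25 umol/kg by the oral route (on this read-out higher numbers stand for a stronger effect at the one dose given and lower numbers for a weaker effect), compound 1 gives 14.1%, the higher of the two numbers, yet compound 2 with 9.88% lies within the scatter of it, so no order between them can be read. Compound 3, `C[C@@H](O)[C@H](NC(=O)CN(c1ncnc2c1ncn2C1CCCCO1)C1CC1)C(=O)OCc1ccccc1`, has not been measured. It differs from compound 1 by 1-hydroxyethyl in place of 2-(benzyloxycarbonyl)ethyl on a saturated chain carbon bound to an amide-type nitrogen and a carbonyl carbon. Going by the values given here, no measured pair shows this change, so its effect is unknown; with both measured numbers at a modest level, a step of a number 2.1 percentage points lower from compound 1 to compound 3 (within the scatter) is expected, not beyond the scatter in either direction. Compound 3 is thus estimated at 12%, with a range from 2% to 30%.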

Compound 3, a percentage reported as activity, at one dose (the size of the read-out at that dose, not a potency): 6.53%
Compound 3: the middle estimate sits 5.5 percentage points above what was measured; the range from low to high includes it.
By their numbers in this assay, from the lowest: compounds 3, 2 and 1 (each within the scatter of the next).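

In this assay, going by these compounds alone, 1-hydroxyethyl in place of 2-(benzyloxycarbonyl)ethyl on a saturated chain carbon bound to an amide-type nitrogen and a carbonyl carbon gives a number 7.6 percentage points lower from compound 1 to compound 3 (within the scatter) and is the first step read at this position. The loss of the side chain's six-membered aromatic ring thus leaves the read-out within the scatter. No available measurement accounts for this result. From the compounds shown here alone, whether an amine, a carboxylic acid or a longer chain at this position would give a step beyond the scatter remains open.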